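The source may hold more compounds than are shown below. What is called first, only, known or untested is meant among the compounds shown, and "the series" means these compounds.

Compound 1 `Cc1ccc(S(=O)(=O)Oc2ccc3c(c2C)[C@H](Cn2cc(-c4ccc(Cl)cc4)nn2)[C@@]24CC(=O)[C@@](C)(CC[C@@H]32)C4)cc1` and compound 2 `Cc1ccc(S(=O)(=O)Oc2ccc3c(c2C)[C@H](Cn2cc(-c4ccccn4)nn2)[C@@]24CC(=O)[C@@](C)(CC[C@@H]32)C4)cc1` share one core and differ only in the group on an aromatic carbon of that core: compound 1 carries a 4-chlorophenyl, compound 2 a pyridin-2-yl. Both were tested in a functional assay on SW480 cells (Homo sapiens) for cytotoxicity, read by MTT assay, with a stated time of 4 days; a lower number here means a stronger inhibitor, a higher number a weaker inhibitor. Compound 1 stops at a limit of the assay, giving > 20000 nM. Compound 2 likewise stops at a limit, giving > 20000 nM. The step that the two limits leave unreadable from compound 1 to compound 2 cannot be read because of the limit of > 20000 nM in this assay, at which 2 of the 2 values shown sit. Compound 2 therefore stands at the limit, without a measured value of its own.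

Compound 3 `COc1ccc(-c2cn(C[C@H]3c4c(ccc(OS(=O)(=O)c5ccc(C)cc5)c4C)[C@@H]4CC[C@@]5(C)C[C@]43CC5=O)nn2)cc1` follows from compound 2 by one change: 4-methoxyphenyl in place of pyridin-2-yl on an aromatic carbon. Going by the values given here, the only measured step that bears on exchanging this aryl group gave no readable size, so there is no measured ground for expecting a shift in this assay in either direction. Compound 3 is therefore expected to sit at or near the same limit, with an estimated value of 30000 nM in a range from 8000 nM to 100000 nM. The expected step that the limit leaves unreadable from compound 2 to compound 3 is none beyond the scatter, and most likely another limit rather than a number.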

Compound 3, half-maximal inhibitory concentration: > 20000 nM
Compound 3 gave a limit, no number; the forecaster's own chance of this, stated with the estimate: 75%; the middle value does not contradict the limit.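

No step can be read from compound 2 to compound 3 or from compound 1 to compound 3, because all three compounds stop at the same limit rather than giving a number: the limit of > 20000 nM in this assay, at which 3 of the 3 values shown sit. Still open, going by these compounds, is whether 4-chlorophenyl, pyridin-2-yl and 4-methoxyphenyl differ at all in this assay, since none of the three compounds gives a measured number there.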